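The source may hold more compounds than are shown below. What is called first, only, known or untested is meant among the compounds shown, and "the series" means these compounds.

Measured in a functional assay on HepG2 cells (Homo sapiens) for cytotoxicity, read by MTT assay, with a stated time of 24 h; a higher number here means a weaker inhibitor, a lower number a stronger inhibitor:
- compound 1 `O=C1/C(=C/c2cccnc2)CN(S(=O)(=O)c2ccc(Cl)cc2)C/C1=C\c1ccccc1F`: 12400 nM
- compound 2 `O=C1/C(=C/c2cccnc2)CN(S(=O)(=O)c2ccc([N+](=O)[O-])cc2)C/C1=C\c1ccccc1C(F)(F)F`: 9370 nM

The set holds only these two numbers. Compound 2 at 9370 nM lies within the usual scatter of compound 1 at 12400 nM, so the two cannot be ranked in this assay.

The next compound to be read is compound 3 `O=C1/C(=C/c2cccnc2)CN(S(=O)(=O)c2ccc(Cl)cc2)C/C1=C\c1ccccc1C(F)(F)F`. Relative to compound 2, the change is chloro in place of nitro on an aromatic carbon, para to a large group, so that 4-nitrophenyl becomes 4-chlorophenyl. The (4-nitrophenyl)sulfonyl group thus becomes (4-chlorophenyl)sulfonyl, and the rest of the structure stays the same.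

For the measured compounds named here, no measured pair isolates this change, so its size cannot be read directly from the data. Going by the values given here, the only guide is the narrow spread of the two values, with compound 1 at 12400 nM and compound 2 at 9370 nM. No shift beyond the scatter is expected in either direction. The estimated step of a 1.1-fold higher number from compound 2 to compound 3 (0.03 log units; within the scatter) is correspondingly small. For compound 3 the estimated value is 10000 nM, with an expected range of 5000 nM to 20000 nM.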

Compound 3, half-maximal inhibitory concentration: 3620 nM
The estimate for compound 3 lay 2.8-fold (0.44 log units) above the measured number; measured number outside the range, below it.
By their numbers in this assay, from the lowest: compound 3; then compounds 2 and 1 (each within the scatter of the next).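

The arylsulfonyl position is not silent in this assay: with the trifluoromethyl group held fixed, chloro in place of nitro on an aromatic carbon, para to a large group, gives a 2.6-fold lower number from compound 2 to compound 3 (0.41 log units; beyond the scatter). For the compounds shown here, the other aryl substituent also matters: with the (4-chlorophenyl)sulfonyl group held fixed, trifluoromethyl in place of fluoro on an aromatic carbon gives a 3.4-fold lower number from compound 1 to compound 3 (0.53 log units; beyond the scatter), so compound 3 links two single-place steps that the earlier compounds, which differ in two places, could not separate. No measurement at hand accounts for either step.

As far as these compounds go, each step rests on a single pair, so it remains open whether the chloro-for-nitro step holds with fluoro in place of trifluoromethyl, and whether the trifluoromethyl-for-fluoro step holds with nitro in place of chloro. Also open, from the compounds shown here alone, is how an amine, a carboxylic acid or a methoxy group would read on the aromatic carbon para to a large group, and hence whether the lower number of compound 3 belongs to chloro specifically or to any replacement of nitro there.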